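This account rests on a few compounds, and the source may have more. Where it says the series, first, only, none or still open, it means among the compounds named here.

Of the compounds shown here, three from this series have been measured in an ADME assay on the whole organism (strain Han-Wistar) for pharmacokinetics, with Rattus norvegicus as the target, read by LC-MS, at a dose of 2 mg/kg by the oral route; a higher number here means more compound in the circulation at the dose given, a lower number less compound in the circulation. Among the compounds with values here, compound 1 `CN1CCN(CCCS(=O)(=O)c2ccc3nc(NC(=O)NC(=O)c4cc(-n5cccc5)ccc4Cl)sc3c2)CC1` gives 580 nM, and compound 2 `Cc1ccn(-c2ccc(Cl)c(C(=O)NC(=O)Nc3nc4ccc(S(=O)(=O)CCCN5CCN(C)CC5)cc4s3)c2)n1` gives 410 nM; the only single-point step among them, a 1.4-fold lower number from compound 1 to compound 2 (0.15 log units; within the scatter), lies within the scatter. Compound 3 `CCN(CC)CCCS(=O)(=O)c1ccc2nc(NC(=O)NC(=O)c3cc(-n4cccn4)ccc3Cl)sc2c1` stands highest of the three with 1600 nM, beyond the scatter above both others. Compound 4 `CN1CCN(CCCS(=O)(=O)c2ccc3nc(NC(=O)NC(=O)c4cc(-n5cccn5)ccc4Cl)sc3c2)CC1` has not yet been measured; it differs from compound 3 in one place: 4-methylpiperazin-1-yl in place of diethylamino on a saturated chain carbon, three bonds along the chain from a sulfonyl sulfur. Within the data shown here, no measured step covers this change directly. Compounds 1 and 2 both carry 4-methylpiperazin-1-yl and both sit well below compound 3, so a drop of about a 2.5-fold lower number from compound 3 to compound 4 (0.39 log units; beyond the scatter) is expected for compound 4 in this assay, estimated at 650 nM with a range of 250 nM to 1600 nM.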

Compound 4, maximal plasma concentration: 1200 nM
Compound 4: the middle estimate sits 1.8-fold (0.27 log units) below what was measured; low and high end bracket the measured number.
By their numbers in this assay, from the lowest: compounds 2 and 1 (each within the scatter of the next); then compounds 4 and 3 (each within the scatter of the next).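

In this assay the exchange of diethylamino for 4-methylpiperazin-1-yl gives a 1.3-fold lower number from compound 3 to compound 4 (0.12 log units; within the scatter) at this place, so the 4-methylpiperazin-1-yl group alone does not set the low numbers of compound 1 and compound 2. With that group kept, the larger steps lie on the aromatic side: a 2.1-fold higher number from compound 1 to compound 4 (0.32 log units; beyond the scatter) for 1H-pyrazol-1-yl in place of 1H-pyrrol-1-yl, and a 2.9-fold higher number from compound 2 to compound 4 (0.47 log units; beyond the scatter) for hydrogen in place of methyl. Nothing shown explains these steps. Open, going by these compounds, is how a morpholine or a piperidine would read in place of either amine, and how a longer chain would read.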